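The compounds below may be only part of what the source reports. "The series", "measured", "known", "first", "only" and "open" are said of these compounds alone.

Series notes. Compound 1 `O=C(CCCCC1CCSS1)NCc1cn(CCCOc2ccc3cc(-c4ccc(Br)cc4)c(=O)oc3c2)nn1` gives in a functional assay on PC-12 cells (Rattus norvegicus) for cytotoxicity, read by MTT assay, with stated times of 3 h and 2 h, tested at 20 uM (on this read-out lower numbers stand for a weaker effect and higher numbers for a stronger effect at the one concentration tested), a value of 69.1%. Compound 2 `O=C(CCCCC1CCSS1)NCc1cn(CCCOc2ccc3cc(-c4ccc(Cl)c(Cl)c4)c(=O)oc3c2)nn1` differs from it by 3,4-dichlorophenyl in place of 4-bromophenyl on an aromatic carbon and gives in this assay a value of 51.2%, a step of a number 17.9 percentage points lower from compound 1 to compound 2 (beyond the scatter). Compound 3 `O=C(CCCCC1CCSS1)NCc1cn(CCCCCOc2ccc3cc(-c4ccc(Br)cc4)c(=O)oc3c2)nn1` carries a different core; the difference between the core of compound 1 and that of compound 3 is not broken down here. In this assay compound 3 gives 52.3%, close to compound 2 and apart from compound 1. Compound 4 `O=C(CCCCC1CCSS1)NCc1cn(CCCCCOc2ccc3cc(-c4ccc(Cl)c(Cl)c4)c(=O)oc3c2)nn1` is not yet measured; it differs from compound 3 by 3,4-dichlorophenyl in place of 4-bromophenyl on an aromatic carbon, the same change as from compound 1 to compound 2, at a place described in the same words. Starting from compound 3 with 52.3%, the step is expected to be a number 14.3 percentage points lower from compound 3 to compound 4 (beyond the scatter), a carry-over of a number 17.9 percentage points lower from compound 1 to compound 2 (beyond the scatter) discounted for resting on a single pair. Compound 4 is therefore estimated at 38%, between 24% and 52%.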

Compound 4, a percentage reported as activity, at one concentration (the size of the read-out at that concentration, not a potency): 65.5%
Compound 4: middle estimate off by 27.5 percentage points, on the low side; the measured number lies above the stated range.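

In this assay, 3,4-dichlorophenyl in place of 4-bromophenyl gives a number 13.2 percentage points higher from compound 3 to compound 4 (beyond the scatter), so the step on the core of compound 1 does not carry over to the core of compound 3, not even in direction: the same change on two cores in this assay, a number 17.9 percentage points lower (beyond the scatter) from compound 1 to compound 2 and a number 13.2 percentage points higher (beyond the scatter) from compound 3 to compound 4, 31.1 percentage points apart, beyond the scatter of two such steps

The size and direction of this change therefore cannot be transferred from one of these cores to the other. Among these compounds, with only two pairs, the data do not show which difference between the cores goes with the reversal, or what the step would be on a further core.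

Open, from the compounds shown here alone, is how a phenyl without halogen, or one carrying a methoxy group or an amine, would behave on these two cores. Going by these compounds, a longer chain in the core also remains open.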